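This account rests on a few compounds, and the source may have more. Where it says the series, first, only, none or still open, it means among the compounds named here.

Three compounds have numbers in a functional assay on HeLa cells (Homo sapiens) for antiproliferative activity, read by MTT assay, with a stated time of 72 h; a higher number here means a weaker inhibitor, a lower number a stronger inhibitor. Compound 1 `O=c1nc2oc(C3CC3)c(C#CC3CC3)c2cn1Cc1cn(-c2ccccc2F)nn1` gives 51200 nM. Compound 2 `O=c1nc2oc(CCCCl)c(C#CCCCCl)c2cn1Cc1cn(Cc2ccccc2)nn1` gives 25400 nM. Compound 3 `O=c1c(I)cn(Cc2cn(Cc3ccccc3)nn2)c(=O)n1Cc1cn(Cc2ccccc2)nn1` gives 15100 nM. Among these, compound 2 stands second highest of the three, and its value lies within the scatter of both compound 3 and compound 1. Compound 4 `O=c1nc2oc(CCCCl)c(C#CCCCCl)c2cn1Cc1cn(-c2ccc(Cl)cc2)nn1` shares the core of compound 2 and differs by 4-chlorophenyl in place of benzyl on an aromatic nitrogen. For the measured compounds named here, no step between measured compounds isolates this change. No step beyond the scatter is expected, because compound 1, which also carries an aryl group in place of benzyl, gives 51200 nM within the scatter of compound 2. Compound 4 is therefore expected to give 35000 nM, between 12000 nM and 100000 nM. The expected step is a 1.4-fold higher number from compound 2 to compound 4 (0.14 log units; within the scatter).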

Compound 4, half-maximal inhibitory concentration: > 100000 nM
Compound 4: a limit, no number; the forecaster's own chance of this, stated with the estimate: 15%; middle value at least 2.8-fold (0.45 log units) away from the limit.
By their numbers in this assay, from the lowest: compounds 3, 2 and 1 (each within the scatter of the next, the first and the last beyond it). At a limit, above all of these: compound 4.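

For the compounds shown here, on an aromatic nitrogen of the five-membered aromatic ring with 3 nitrogen, 4-chlorophenyl in place of benzyl is the first single change that can be read in this assay, and it gives an at least 3.9-fold higher number from compound 2 to compound 4 (0.59 log units; beyond the scatter). Compound 4 gives a limit of the assay and not a number: > 100000 nM. This position is thus not indifferent to its group, although both groups hold one six-membered aromatic ring of carbon only.

The compounds shown do not separate the chlorine from the shift of benzyl to a directly attached ring, which plain phenyl or 4-chlorobenzyl on the core of compound 2 would do. From the compounds shown here alone, how an amine on this ring would read also stays open.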